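Extending the Chain with a Hydroxymethyl Group

A few compounds are considered here, and "the series" means these few. Any claim that something is new, unique, unknown or untested is made for them only; others in the source may bear on it.

Compound 1 `CCN(c1ccnc(Nc2ccc(C#N)cc2)n1)c1c(F)cc(-c2ccc(C#N)cc2)cc1F` is the starting point of this account. In an ADME assay on MT4 cells (Homo sapiens) for cytotoxicity, read by MTT assay, with a stated time of 5 days (a lower number here means that less compound is tolerated, a higher number that more compound is tolerated), compound 1 gives 105000 nM, the lowest of the two plain numbers in this set. Compound 2 `CCCN(c1ccnc(Nc2ccc(C#N)cc2)n1)c1c(F)cc(-c2ccc(C#N)cc2)cc1F` carries a methyl in place of hydrogen on the saturated chain carbon, and in this assay compound 2 gives 212000 nM; the step is a 2.0-fold higher number from compound 1 to compound 2 (0.31 log units; beyond the scatter). Compound 3 `CCC(C)CN(c1ccnc(Nc2ccc(C#N)cc2)n1)c1c(F)cc(-c2ccc(C#N)cc2)cc1F` gives > 255000 nM in this assay, which is a limit of the assay rather than a number, as noted in the limit of > 255000 nM in this assay, at which 1 of the 3 values shown sits. The step of an at least 2.4-fold higher number from compound 1 to compound 3 (0.38 log units; beyond the scatter) therefore has only a floor.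

The unmeasured compound 4 `N#Cc1ccc(Nc2nccc(N(CCCO)c3c(F)cc(-c4ccc(C#N)cc4)cc3F)n2)cc1` differs from compound 1 by hydroxymethyl in place of hydrogen on a saturated chain carbon, two bonds along the chain from a nitrogen on an aromatic ring. The steps from compound 1 to compound 2 and to compound 3 both raised the number when the chain was lengthened at this position, so a modest rise is expected here too, though the entering group is different from an alkyl. He estimates that compound 4 gives 160000 nM in this assay, between 80000 nM and 300000 nM, a step of a 1.5-fold higher number from compound 1 to compound 4 (0.18 log units; within the scatter) that is expected to stay near the edge of the scatter.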

Compound 4, half-maximal cytotoxic concentration: 68000 nM
Estimate against measurement, compound 4: 2.4-fold (0.37 log units) above; the whole stated range lies above it.
By their numbers in this assay, from the lowest: compounds 4 and 1 (each within the scatter of the next); then compound 2. At a limit, above all of these: compound 3.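

At this place, a saturated chain carbon three bonds along the chain from a nitrogen on an aromatic ring, hydroxy in place of hydrogen turns the alkyl trend around in this assay, giving a 3.1-fold lower number from compound 2 to compound 4 (0.49 log units; beyond the scatter). Measured against the shorter chain, the hydroxymethyl change gives no readable difference, a 1.5-fold lower number from compound 1 to compound 4 (0.19 log units; within the scatter), so the rise seen with the alkyl chains does not appear in compound 4. The step from the sec-butyl chain points the same way, an at least 3.7-fold lower number from compound 3 to compound 4 (0.57 log units; beyond the scatter), and compound 3 stands at a limit of the assay, not at a number: the limit of > 255000 nM in this assay, at which 1 of the 4 values shown sits.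

The compounds shown leave open whether an amine, a methyl ether or a carboxylic acid at this same place would behave as the hydroxy does. They also leave open what a longer chain ending in hydroxy would give.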